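A few compounds are considered here, and "the series" means these few. Any claim that something is new, unique, unknown or untested is made for them only; others in the source may bear on it.

Measured in a functional assay on U-937 cells (Homo sapiens), read by cAMP accumulation; a lower number here means that less compound is needed, a higher number that more compound is needed for the effect:
- compound 1 `CCc1nn(-c2ccc(F)cc2)c2c1CCN(c1ccccc1)C2=O`: 880 nM
- compound 2 `CCc1nn(C2CCCC2)c2c1CCN(c1ccccc1C)C2=O`: 330 nM
- compound 3 `CCc1nn(C2CCS(=O)(=O)C2)c2c1CCN(c1cccc(OC)c1)C2=O`: 5270 nM

Compound 2 stands lowest of the three at 330 nM, so it needs the least compound for the effect. Compound 1 and compound 3 both lie above it, beyond the scatter.

Compound 4 `CCc1nn(C2CCCC2)c2c1CCN(Cc1ccccc1)C2=O` has the same atoms as compound 2, joined differently: benzyl in place of 2-methylphenyl on an amide-type nitrogen in a ring. The size of this change is hard to judge. Among the measured compounds shown here, no two measured compounds differ in only one place, and none carries benzyl on that nitrogen. The three values do show that this family spans a wide range in this assay. With compound 2 already lowest at 330 nM, a rise looks likelier than a further fall, although this is only a tentative expectation. The expected change is a 3.0-fold higher number from compound 2 to compound 4 (0.48 log units; beyond the scatter), a moderate move toward a higher number, probably beyond the scatter. For compound 4 the estimated value is 1000 nM, with an expected range of 230 nM to 5000 nM.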

Compound 4, half-maximal effective concentration: 36 nM
For compound 4 the middle estimate is 28-fold (1.44 log units) above the measured one, outside the stated range (below it).
By their numbers in this assay, from the lowest: compound 4; then compound 2; then compound 1; then compound 3.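

In this assay, placing benzyl instead of 2-methylphenyl on the amide-type nitrogen in a ring gives a 9.2-fold lower number from compound 2 to compound 4 (0.96 log units; beyond the scatter). The two groups hold the same atoms and the same kind of aromatic ring, so this position is sensitive to how those atoms are joined, not only to which atoms are present. Nothing available explains why the number falls.

As far as these compounds go, this is a single pair, so it remains unknown whether benzyl would bring a similar fall alongside the other groups on the shared core in compound 1 and compound 3. From the compounds shown here alone, it is also open whether a longer chain such as phenylethyl, or a ring-substituted group such as methoxybenzyl, on the same nitrogen would lower the number further or raise it again.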